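Compound 1 and its 2-carboxypyrrolidin-1-yl counterpart

The compounds below may be only part of what the source reports. "The series", "measured", "known", "first", "only" and "open" are said of these compounds alone.

Compound 1 `CC[C@H](C)[C@H](NCC(=O)NNC(=O)COc1ccc(-c2nc3ccccc3s2)cc1OC)C(=O)O` gives 1710 nM 
Compound 2 `COc1cc(-c2nc3ccccc3s2)ccc1OCC(=O)NNC(=O)CN[C@@H](CCSC)C(=O)O` gives 1950 nM 
Compound 3 `COc1cc(-c2nc3ccccc3s2)ccc1OCC(=O)NNC(=O)CNC(=N)NCCC[C@H](N[N+](=O)[O-])C(=O)O` gives 1960 nM 

These three compounds were tested in a functional assay on MCF7 cells (Homo sapiens) for inhibition, read by MTT assay, with a stated time of 3 days (on this read-out lower numbers stand for stronger inhibition and higher numbers for weaker inhibition), and share one core. Compound 1 stands level with the other two: the three values lie within the usual scatter of one another.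

Compound 4 `COc1cc(-c2nc3ccccc3s2)ccc1OCC(=O)NNC(=O)CN1CCC[C@H]1C(=O)O` has not yet been measured. The change from compound 1 is 2-carboxypyrrolidin-1-yl in place of (1-carboxy-2-methylbutyl)amino on a saturated chain carbon bound to a carbonyl carbon and it lies on a saturated chain carbon bound to a carbonyl carbon. In words, 2-carboxypyrrolidin-1-yl takes the place of (1-carboxy-2-methylbutyl)amino, so the new group brings one five-membered non-aromatic ring with 1 hetero atom.

Among the measured compounds shown here, the one measured step that bears on this is a 1.1-fold higher number from compound 1 to compound 2 (0.06 log units; within the scatter) and there 2-(methylsulfanyl)ethyl stands in place of sec-butyl. That swap left the number within the scatter. Compound 3 carries a different group again and gives 1960 nM in the same narrow band. None of the three measured compounds carries the new ring, so the data offer no direct test of it.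

What is expected in this assay is therefore a 1.1-fold higher number from compound 1 to compound 4 (0.05 log units; within the scatter) which amounts to no expected step beyond the scatter. For compound 4 the estimated value is 1900 nM with an expected range from 900 nM to 4000 nM and this range is kept wide.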

Compound 4, half-maximal inhibitory concentration: 840 nM
The estimate for compound 4 lay 2.3-fold (0.35 log units) above the measured number, and the stated range ends above it.
By their numbers in this assay, from the lowest: compound 4; then compounds 1, 2 and 3 (each within the scatter of the next).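

In this assay the position on a saturated chain carbon bound to a carbonyl carbon turns out to respond to a change, something the earlier swap of one open side chain for another did not show. With 2-carboxypyrrolidin-1-yl entering, which brings one five-membered non-aromatic ring with 1 hetero atom, the steps are modest but lie beyond the scatter (a 2.0-fold lower number from compound 1 to compound 4 (0.31 log units; beyond the scatter)) and (a 2.3-fold lower number from compound 2 to compound 4 (0.37 log units; beyond the scatter)), so the same kind of replacement moves the number in the same direction from two different open-chain starting points. Nothing available here explains why the ring form gives the lower number.

Among the compounds shown here, with only one ring-bearing compound, these data cannot separate the effect of closing the ring from the loss of the open side chain, so it is unclear which feature of 2-carboxypyrrolidin-1-yl matters. Going by these compounds, it also remains open whether the carboxylic acid on the ring is needed, a question that a methyl ester or a primary amide at that spot would address, and whether the opposite configuration at the ring's stereocentre would give a similar number.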